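Enlarging the acyl group on the thiazole-fused piperidine core

This account rests on a few compounds, and the source may have more. Where it says the series, first, only, none or still open, it means among the compounds named here.

Compound 1 `CCCCN1CCc2nc(C#Cc3ccccc3)sc2C1` — > 10000 nM
Compound 2 `CC(C)CN1CCc2nc(C#Cc3ccccc3)sc2C1` — 650 nM
Compound 3 `CC(=O)N1CCc2nc(C#Cc3ccccc3)sc2C1` — 90 nM

In an assay on HEK293 cells for negative allosteric modulation of metabotropic glutamate receptor 5 (Homo sapiens), read by FLIPR, with a stated time of 1 h (a higher number here means a weaker inhibitor, a lower number a stronger inhibitor), compound 1 gives only a limit, > 10000 nM (the limit of > 10000 nM in this assay, at which 1 of the 3 values shown sits). Compound 3 stands lowest of the two numbers shown; the nearest is compound 2, and the step of a 7.2-fold lower number from compound 2 to compound 3 (0.86 log units; beyond the scatter) lies beyond the scatter, as does an at least 110-fold lower number from compound 1 to compound 3 (2.04 log units; beyond the scatter). Compound 4 `O=C(C1CC12CCC2)N1CCc2nc(C#Cc3ccccc3)sc2C1` differs from compound 3 in one place: a group of 6 heavy atoms (6 carbon; one three-membered non-aromatic ring of carbon only, one four-membered non-aromatic ring of carbon only) in place of one carbon atom, on a carbonyl carbon. Going by the values given here, no measured step varies the acyl group itself; the steps of an at least 15-fold lower number from compound 1 to compound 2 (1.18 log units; beyond the scatter) and a 7.2-fold lower number from compound 2 to compound 3 (0.86 log units; beyond the scatter) show that a branched or acyl substituent on the ring nitrogen gives lower numbers. The same amide type is kept, so compound 4 is expected to give 60 nM (range 15 nM to 400 nM), a step of a 1.5-fold lower number from compound 3 to compound 4 (0.18 log units; within the scatter) within the scatter.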

Compound 4, half-maximal inhibitory concentration: > 10000 nM
Compound 4 ended at the assay's limit; the forecaster's own chance of this, stated with the estimate: 5%; at least 160-fold (2.22 log units) between middle value and limit.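

On the carbonyl carbon, keeping the amide type does not protect the result: the group with a three-membered and a four-membered carbon ring in place of methyl gives an at least 110-fold higher number from compound 3 to compound 4 (2.04 log units; beyond the scatter), so this position does not accept every larger group. On the amine nitrogen in a ring, the same acyl group also compares poorly with isobutyl, with an at least 15-fold higher number from compound 2 to compound 4 (1.18 log units; beyond the scatter). Compound 4 gives only a limit, and its step from compound 1, also a limit, cannot be read: the limit of > 10000 nM in this assay, at which 2 of the 4 values shown sit.

As far as these compounds go, whether an ethyl, a cyclopropyl or a tert-butyl on the carbonyl carbon keeps the number of compound 3 stays open. Also open, from the compounds shown here alone, is whether the loss follows the size of the group or the two rings themselves.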